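Aryl ether variations in a phenoxyethylamine antagonist series

This account rests on a few compounds, and the source may have more. Where it says the series, first, only, none or still open, it means among the compounds named here.

Measured compounds:
compound 1, `COc1cccc(OC)c1OCCNCCOc1ccccc1OCc1ccccc1Cl`: 8.59
compound 2, `COc1ccc(COc2ccccc2OCCNCCOc2c(OC)cccc2OC)cc1`: 9.21

In a functional assay on thoracic aorta for antagonist activity at Alpha-1D adrenergic receptor (Rattus norvegicus) (a higher number here means a more potent compound, by a factor of ten per unit of this negative logarithm, a lower number a less potent compound), compound 2 gives 9.21, the highest of the two numbers in hand. The nearest is compound 1 with 8.59, and the step of a number 0.62 log units higher from compound 1 to compound 2 (beyond the scatter) lies beyond the scatter.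

Compound 3 `COc1cccc(OC)c1OCCNCCOc1ccccc1OCc1ccc(OC(C)C)cc1` differs from compound 2 by isopropyl in place of methyl on an oxygen on an aromatic ring. Within the data shown here, no measured step alters the group on that oxygen; the only step known, a number 0.62 log units higher from compound 1 to compound 2 (beyond the scatter), exchanges the whole aryl group rather than the alkyl on the oxygen, so it does not bear directly on this change. With nothing in the series to suggest a direction, the expected step of a number 0.21 log units lower from compound 2 to compound 3 (within the scatter) is none beyond the scatter, with the range widened for the lack of a precedent. For compound 3 the estimate in this assay is 9, spanning 8.4 to 9.6.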

Compound 3, negative logarithm of the antagonist equilibrium constant: 9.14
The estimate for compound 3 lay 0.14 log units below the measured number; the measured number falls inside the stated range.
By their numbers in this assay, from the lowest: compound 1; then compounds 3 and 2 (each within the scatter of the next).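

In this assay, the oxygen on the aromatic ring carries isopropyl as well as methyl with no separation between the two compounds: the step is a number 0.07 log units lower from compound 2 to compound 3 (within the scatter) and so gives no order between 4-methoxyphenyl and 4-isopropoxyphenyl. The advantage over 2-chlorophenyl does not depend on methyl alone, as 4-isopropoxyphenyl also stands clear of it, with a number 0.55 log units higher from compound 1 to compound 3 (beyond the scatter) as the step. No supporting data on these compounds bear on why methoxy and isopropoxy read alike.

Going by these compounds, whether this tolerance extends to a longer chain or a benzyl group on the same oxygen remains open, as does the outcome with a free hydroxyl in place of the alkoxy group. Also open, on these data alone, is how an amine at that point on the aryl group would read.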